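Methoxy in place of bromo on compound 3

The source may report more compounds than this note shows. Statements on the series, on what has been measured and on what is new or still open speak of the compounds shown alone.

Measured in a functional assay on the whole organism (strain Kunming) with Mus musculus as the target, with a stated time of 0.5 h; a lower number here means that less compound is needed, a higher number that more compound is needed for the effect:
- compound 1 `COc1ccccc1/C=C/C(=O)OC/C=C/c1cc(OC)c(OC)cc1OC` gives 101 umol/kg
- compound 2 `COc1cc(OC)c(OC)cc1/C=C/COC(=O)/C=C/c1cc(OC)c(OC)c(OC)c1OC` gives 65.1 umol/kg
- compound 3 `COc1cc(OC)c(OC)cc1/C=C/COC(=O)/C=C/c1cccc(Br)c1` gives 175 umol/kg

Compound 3 lies within the scatter of compound 1 and carries a higher number than compound 2, a gap beyond the scatter. Compound 4 `COc1cccc(/C=C/C(=O)OC/C=C/c2cc(OC)c(OC)cc2OC)c1` has methoxy in place of bromo on an aromatic carbon, which turns 3-bromophenyl into 3-methoxyphenyl. Among the measured compounds shown here, the one measured step that bears on this is a 1.7-fold higher number from compound 1 to compound 3 (0.24 log units; within the scatter), where 3-bromophenyl replaces 2-methoxyphenyl. That step stays within the scatter, so no step beyond the scatter is expected in this assay. The expected step, which leans towards the methoxy-bearing compound 1, is a 1.6-fold lower number from compound 3 to compound 4 (0.20 log units; within the scatter). For compound 4 the estimate is 110 umol/kg, expected to fall between 55 umol/kg and 210 umol/kg.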

Compound 4, dose for half-maximal effect: 190 umol/kg
Compound 4: middle estimate off by 1.7-fold (0.24 log units), on the low side; measured number inside the range.
By their numbers in this assay, from the lowest: compounds 2, 1, 3 and 4 (each within the scatter of the next, the first and the last beyond it).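

In this assay methoxy in place of bromo on this aromatic carbon gives a 1.1-fold higher number from compound 3 to compound 4 (0.04 log units; within the scatter) and does not separate the two groups. 3-Methoxyphenyl in place of 2-methoxyphenyl gives a 1.9-fold higher number from compound 1 to compound 4 (0.27 log units; within the scatter) and so does not separate these two placements of methoxy either. Neither change produces a step beyond the scatter in these compounds.

From the compounds shown here alone, whether an amine or a carboxylic acid on this aromatic carbon would produce such a step remains open. Nothing at hand explains why these steps stay so small.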